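The compounds below may be only part of what the source reports. "The series", "measured", "known", "first", "only" and "open" are said of these compounds alone.

Series notes. In an assay on isolated protein for inhibition of coagulation factor X (Oryctolagus cuniculus), tested at 1 uM (on this read-out higher numbers stand for more inhibition at the one concentration tested (going by the name of the read-out) and lower numbers for less inhibition), compound 1 `O=C1[C@@H](NS(=O)(=O)c2ccc(-c3ccon3)s2)CCN1CCNc1ccncc1` gives 22% and stands second highest of the three measured numbers. Compound 3 `O=C1[C@@H](NS(=O)(=O)c2ccc(-c3ccon3)s2)CCN1Cc1cc2c[nH]ccc-2n1` gives 17%; the step is a number 5 percentage points lower from compound 1 to compound 3 (within the scatter). Compound 2 `O=C1[C@@H](NS(=O)(=O)c2nc3cc(Cl)ccc3[nH]2)CCN1Cc1cc2c[nH]ccc-2n1` gives 31%. Compound 4 `O=C1[C@@H](NS(=O)(=O)c2ccc(-c3ccncc3)s2)CCN1CCNc1ccncc1` differs from compound 1 as pyridin-4-yl in place of 1,2-oxazol-3-yl on an aromatic carbon. For the measured compounds named here, no measured step alters this group alone: the step of a number 14 percentage points lower from compound 2 to compound 3 (beyond the scatter) exchanges the whole group on the sulfonyl sulfur, and the step from compound 1 to compound 3 sits at another place. Going by the values given here, the one exchange on the sulfonyl sulfur moved the read-out only modestly, so compound 4 is expected to stay near compound 1, with the step of a number 3 percentage points higher from compound 1 to compound 4 (within the scatter) expected within the scatter. Compound 4 is estimated at 25%, range 5% to 45%.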

Compound 4, a percentage reported as inhibition, at one concentration (the size of the read-out at that concentration, not a potency): 41%
The estimate for compound 4 lay 16 percentage points below the measured number; measured number inside the range.
By their numbers in this assay, from the lowest: compounds 3, 1, 2 and 4 (each within the scatter of the next, the first and the last beyond it).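

In this assay, for the compounds shown here, pyridin-4-yl in place of 1,2-oxazol-3-yl gives a number 19 percentage points higher from compound 1 to compound 4 (beyond the scatter) and is the first change read at this place alone, on an aromatic carbon of a five-membered aromatic ring with 1 sulfur. The group at this place thus moves the read-out by itself, which the exchange of the whole group on the sulfonyl sulfur could not separate. Nothing available accounts for the size of this step.

On these data alone, whether the pyridine nitrogen matters stays open, and a phenyl or pyridin-3-yl group here would test it. Also open, as far as these compounds go, is whether the step holds with the group of compound 3 on the ring amide-type nitrogen.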